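Tert-butoxycarbonyl in place of hydrogen on the ring amine

A few compounds are considered here, and "the series" means these few. Any claim that something is new, unique, unknown or untested is made for them only; others in the source may bear on it.

Measured so far in a functional assay on ECa-109 cells (Homo sapiens) for inhibition, read by MTT assay, with a stated time of 72 h; a lower number here means a stronger inhibitor, a higher number a weaker inhibitor:
compound 1 `COc1ccc(Cn2cc(CSC(=S)N3CCN(C(=O)OC(C)(C)C)CC3)nn2)cc1` gives 36800 nM
compound 2 `Cc1ccc(Cn2cc(CSC(=S)N3CCN(C(=O)OCc4ccccc4)CC3)nn2)cc1` gives 32600 nM
compound 3 `Cc1ccc(Cn2cc(CSC(=S)N3CCNCC3)nn2)cc1` gives > 128000 nM

Compound 3 stands at the weak end of the set: its value in this assay is a limit of the assay rather than a number, the one shown at the limit of > 128000 nM in this assay, at which 1 of the 3 values shown sits. Compound 1 and compound 2 each carry a carbonyl-bearing group on the ring amine nitrogen, tert-butoxycarbonyl in compound 1 and benzyloxycarbonyl in compound 2, and both give measured numbers of similar size.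

The next compound is compound 4 `Cc1ccc(Cn2cc(CSC(=S)N3CCN(C(=O)OC(C)(C)C)CC3)nn2)cc1`. Relative to compound 3 the change is tert-butoxycarbonyl in place of hydrogen on an amine nitrogen in a ring. For the measured compounds named here, the one measured step that bears on it is an at least 3.9-fold higher number from compound 2 to compound 3 (0.59 log units; beyond the scatter), the same kind of change run backwards with benzyloxycarbonyl instead of tert-butoxycarbonyl. Restoring a carbamate-type group is therefore expected to move the number down, out of the limit and into the range where compound 1 and compound 2 sit.

Compound 4 is expected to give about 36000 nM, with a likely range from 18000 nM to 75000 nM. The expected step is an at least 3.5-fold lower number from compound 3 to compound 4 (0.55 log units; beyond the scatter).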

Compound 4, half-maximal inhibitory concentration: 47900 nM
Compound 4: the middle estimate sits 1.3-fold (0.12 log units) below what was measured, within the range that was stated.
By their numbers in this assay, from the lowest: compounds 2, 1 and 4 (each within the scatter of the next). At a limit, above all of these: compound 3.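

In this assay the ring amine nitrogen responds to what it carries on a single unchanged core, with an at least 2.6-fold lower number from compound 3 to compound 4 (0.42 log units; beyond the scatter) for tert-butoxycarbonyl in place of hydrogen. Two other changes stay within the scatter: tert-butyl in place of benzyl on the oxygen gives a 1.5-fold higher number from compound 2 to compound 4 (0.17 log units; within the scatter), and methyl in place of methoxy on an aromatic carbon gives a 1.3-fold higher number from compound 1 to compound 4 (0.11 log units; within the scatter), so neither separates these compounds. Compound 3 has only a limit and not a number, so the full size of the first step stays unknown: the limit of > 128000 nM in this assay, at which 1 of the 4 values shown sits.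

As far as these compounds go, whether the gain needs a carbamate at all stays open, and an acetyl amide or a plain benzyl on the ring amine nitrogen would test that. Also open, from the compounds shown here alone, is how a chlorine or a nitrile on the aromatic ring would read.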